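The source may report more compounds than this note shows. Statements on the series, on what has been measured and on what is new or still open speak of the compounds shown alone.

Measured compounds in an assay on membranes from liver for displacement of a labelled ligand from Glucagon receptor (Mus musculus), read by scintillation counting, with a stated time of 60 min; a lower number here means a stronger inhibitor, a higher number a weaker inhibitor:
compound 1 `C[C@H](c1ccc(C(=O)NCCC(=O)O)cc1)N1C(=O)C(c2cccc(F)c2)=N[C@]12CC[C@@H](C(C)(C)C)CC2` gives 4400 nM;
compound 2 `CCC[C@H](c1ccc(C(=O)NCc2nn[nH]n2)cc1)N1C(=O)C(c2cc(Cl)cc(Cl)c2)=N[C@]12CC[C@@H](C(C)(C)C)CC2` gives 500 nM;
compound 3 `CC(C)(C)[C@H]1CC[C@]2(CC1)N=C(c1ccc(C(F)(F)F)cc1)C(=O)N2Cc1ccc(C(=O)NCCC(=O)O)cc1` gives 9600 nM.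

Among these three, compound 1 stands second highest in this assay. Its nearest neighbour is compound 3, whose number is higher, with a gap beyond the usual scatter; compound 2 lies furthest away, with a lower number, also beyond the scatter. Compound 4 `C[C@H](c1ccc(C(=O)NCCC(=O)O)cc1)N1C(=O)C(c2cccc(OC(F)(F)F)c2)=N[C@]12CC[C@@H](C(C)(C)C)CC2` is not yet measured. It differs from compound 1 in one place: trifluoromethoxy in place of fluoro on an aromatic carbon, on an aromatic carbon of a six-membered aromatic ring of carbon only, meta to a large group. Among the measured compounds shown here, no step between two measured compounds isolates this change, so the expectation rests on compound 1 alone. The author expects a modest step toward a lower number, a 2.2-fold lower number from compound 1 to compound 4 (0.34 log units; beyond the scatter), at about the edge of the scatter. Compound 4 is accordingly estimated at 2000 nM, within 600 nM to 6500 nM in this assay.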

Compound 4, half-maximal inhibitory concentration: 1500 nM
The estimate for compound 4 lay 1.3-fold (0.12 log units) above the measured number, within the range that was stated.
By their numbers in this assay, from the lowest: compound 2; then compound 4; then compound 1; then compound 3.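

In this assay, among the compounds shown here, the change from 3-fluorophenyl to 3-(trifluoromethoxy)phenyl gives the first reading of this position with the rest of the molecule held constant (a 2.9-fold lower number from compound 1 to compound 4 (0.47 log units; beyond the scatter)). The earlier compounds shown here differ from one another in more than one place, so they could not show that this substitution alone moves the number, or in which direction. Nothing available explains the step.

From the compounds shown here alone, whether a methoxy or a nitrile on this aromatic carbon would give a similar step remains open. So does whether the step would carry over to a core bearing a different side chain.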